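Replacing trifluoromethoxy with methyl in compound 2

The source may report more compounds than this note shows. Statements on the series, on what has been measured and on what is new or still open speak of the compounds shown alone.

In a functional assay on A549 cells (Homo sapiens) for antiproliferative activity, read by MTT assay, with a stated time of 72 h (on this read-out lower numbers stand for stronger inhibition and higher numbers for weaker inhibition), compound 1 `O=S1(=O)C=Cc2ccc(Nc3ccc(F)c(F)c3)cc21` gives 1550 nM, compound 2 `O=S1(=O)C=Cc2cccc(Nc3ccc(OC(F)(F)F)cc3)c21` gives 1570 nM and compound 3 `O=S1(=O)C=Cc2cccc(Nc3cccc(F)c3)c21` gives 2550 nM. Compound 2 thus stands within the scatter of both other compounds, and these numbers support no ranking among the three. Compound 4 `Cc1ccc(Nc2cccc3c2S(=O)(=O)C=C3)cc1` has not yet been measured. It carries methyl in place of trifluoromethoxy on an aromatic carbon, para to a large group: methyl in place of trifluoromethoxy on an aromatic carbon. For the measured compounds named here, no measured pair shows what this replacement does. The expected change in this assay is therefore none beyond the scatter, with no firm direction, and the estimated step is a 1.3-fold higher number from compound 2 to compound 4 (0.11 log units; within the scatter). For compound 4 the estimate is 2000 nM, with an expected range from 700 nM to 6000 nM.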

Compound 4, half-maximal inhibitory concentration: 2680 nM
For compound 4 the middle estimate is 1.3-fold (0.13 log units) below the measured one, and the stated range covers the measured number.
By their numbers in this assay, from the lowest: compounds 1, 2, 3 and 4 (each within the scatter of the next).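

In this assay, this first pair for the change gives a 1.7-fold higher number from compound 2 to compound 4 (0.23 log units; within the scatter). At this place, on an aromatic carbon para to a large group, methyl can therefore stand in for trifluoromethoxy with no difference that this read-out separates from the scatter. No measurement at hand bears on why this is so. The compounds shown leave open whether an amine, a carboxylic acid or a longer chain at the same place would move the number beyond the scatter.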